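A few compounds are considered here, and "the series" means these few. Any claim that something is new, unique, unknown or untested is made for them only; others in the source may bear on it.

Working notes on the series.

Compound 1 `N#CC1(NC(=O)[C@@H](CC(=O)N2CCOCC2)CC2CCCCC2)CC1` and compound 2 `N#C[C@@]1(NC(=O)[C@@H](CC(=O)N2CCOCC2)CC2CCCCC2)CCNC1` share the core with compound 3 `N#C[C@H](CCc1ccccc1)NC(=O)[C@@H](CC(=O)N1CCOCC1)CC1CCCCC1` and differ from it only in the group on the amide-type nitrogen. In an assay on isolated protein for inhibition of cathepsin S (Homo sapiens) (on this read-out lower numbers stand for stronger inhibition and higher numbers for weaker inhibition), compound 1 gives 135 nM, compound 2 gives 141 nM, and the step of a 1.0-fold higher number from compound 1 to compound 2 (0.02 log units; within the scatter) lies within the scatter. Compound 3 gives 171 nM in this assay; its gap to compound 2 and to compound 1 is also within the scatter, so on these numbers the three stand together.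

Compound 4 `N#C[C@H](COCc1ccccc1)NC(=O)[C@@H](CC(=O)N1CCOCC1)CC1CCCCC1` differs from compound 3 by benzyloxy in place of benzyl on a saturated chain carbon, two bonds along the chain from an amide-type nitrogen and a triple-bonded carbon. Among the measured compounds shown here, no measured step touches this part of the molecule: the only step at hand, from compound 1 to compound 2, concerns the other side of the amide and is itself within the scatter. There is therefore no basis for expecting a shift beyond the scatter in this assay, in either direction; the step of a 1.0-fold lower number from compound 3 to compound 4 (0.00 log units; within the scatter) is expected to be flat. Compound 4 is estimated at 170 nM in this assay, with a range from 70 nM to 420 nM.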

Compound 4, half-maximal inhibitory concentration: 37 nM
Compound 4: middle estimate off by 4.6-fold (0.66 log units), on the high side, and the stated range ends above it.
By their numbers in this assay, from the lowest: compound 4; then compounds 1, 2 and 3 (each within the scatter of the next).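

In this assay, benzyloxy in place of benzyl on a saturated chain carbon, two bonds along the chain from an amide-type nitrogen and a triple-bonded carbon, gives a 4.6-fold lower number from compound 3 to compound 4 (0.66 log units; beyond the scatter). Among the compounds shown here, this is the first step beyond the scatter, whereas a 1.0-fold higher number from compound 1 to compound 2 (0.02 log units; within the scatter) stayed within it, so a change at this position can move the number even with the aromatic ring kept and one oxygen, counted as one hydrogen-bond acceptor, added. No measurement at hand bears on why the number moves.

The compounds shown leave open whether the oxygen itself or the added chain atom carries the step, a question that a longer all-carbon chain or a sulfur ether in the same place would address. Also open, on these data alone, is how an amine at this place in the chain would read.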